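From Thiophen-3-yl to 1-Benzofuran-2-yl at the Limit

The source may hold more compounds than are shown below. What is called first, only, known or untested is meant among the compounds shown, and "the series" means these compounds.

In a functional assay on HCT-116 cells (Homo sapiens), read by MTT assay, with a stated time of 72 h (on this read-out lower numbers stand for stronger inhibition and higher numbers for weaker inhibition), compound 1 (`Nc1nc(N)c2c(-c3ccco3)cn([C@@H]3O[C@H](CO)[C@@H](O)[C@H]3O)c2n1`) gives > 20000 nM as its reading, which is a limit and not a number. Compound 2 (`Nc1nc(N)c2c(-c3ccsc3)cn([C@@H]3O[C@H](CO)[C@@H](O)[C@H]3O)c2n1`) gives > 20000 nM as its reading, again a limit. Within the data shown here, the two compounds thus share one place (the limit of > 20000 nM in this assay, at which 2 of the 2 values shown sit), and the only measured step (a step that the two limits leave unreadable from compound 1 to compound 2) has no size to carry forward.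

Compound 3 (`Nc1nc(N)c2c(-c3cc4ccccc4o3)cn([C@@H]3O[C@H](CO)[C@@H](O)[C@H]3O)c2n1`) keeps the shared core and changes one group (1-benzofuran-2-yl in place of thiophen-3-yl on an aromatic carbon), with 1-benzofuran-2-yl in place of thiophen-3-yl on an aromatic carbon. This brings in one six-membered aromatic ring of carbon only.

Among the measured compounds shown here, compound 2 offers only its limit of > 20000 nM as a starting point, so no measured step predicts a gain or a loss. The expected step (a number no higher from compound 2 to compound 3 (the limit leaves the size open)) is none beyond the scatter in this assay and another limit is the likeliest report. Compound 3 is expected at 20000 nM with an estimated range of 8000 nM to 50000 nM for this half-maximal inhibitory concentration.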

Compound 3, half-maximal inhibitory concentration: > 20000 nM
Compound 3 was reported as a limit; the forecaster's own chance of this, stated with the estimate: 80%; the middle value lies on the limit itself.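

Compound 1, compound 2 and compound 3 each give a limit rather than a number in this assay, so no step among them can be read: the limit of > 20000 nM in this assay, at which 3 of the 3 values shown sit.

The compounds shown leave open whether furan-2-yl, thiophen-3-yl and 1-benzofuran-2-yl differ at all in this read-out.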